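A few compounds are considered here, and "the series" means these few. Any claim that something is new, unique, unknown or untested is made for them only; others in the source may bear on it.

Of the compounds shown here, three that share one core have been measured in an assay on MDA-MB-231 cells for displacement of a labelled ligand from C-X-C chemokine receptor type 4 (Homo sapiens), read by fluorescence and microscopy, with stated times of 10 min and 30 min; on this read-out lower numbers stand for an effect already at smaller amounts and higher numbers for an effect only at larger amounts of compound. In this assay compound 1 `Cc1cccc(S(=O)(=O)NCc2ccc(CNC(=O)c3cccnc3)cc2)c1` gives 10 nM. Compound 2 `COc1ccccc1C(=O)NCc1ccc(CNS(=O)(=O)c2cccc(C)c2)cc1` gives 1000 nM, and compound 3 `Cc1cccc(S(=O)(=O)NCc2ccc(CNC(=O)c3ccccc3C)cc2)c1` gives 1000 nM. Compound 3 thus stands level with compound 2, and the pair sit together at the highest numbers of the three; the larger gap appears as a 100-fold higher number from compound 1 to compound 3 (2.00 log units; beyond the scatter), while no change at the digits printed from compound 2 to compound 3 (within the scatter) shows nothing beyond the scatter.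

Compound 4 `Cc1ccccc1C(=O)NCc1ccc(CNS(=O)(=O)c2ccc([N+](=O)[O-])cc2)cc1` differs from compound 3 in one place: 4-nitrophenyl in place of 3-methylphenyl on a sulfonyl sulfur. Within the data shown here, none of the measured steps touches this part of the molecule. The steps of a 100-fold higher number from compound 1 to compound 2 (2.00 log units; beyond the scatter) and a 100-fold higher number from compound 1 to compound 3 (2.00 log units; beyond the scatter) change the group on the carbonyl carbon, and the step from compound 2 to compound 3 swaps methyl for methoxy on that same side. The sulfonyl side stays fixed throughout, so no direct guide exists, and the expectation defaults to a step near none beyond the scatter, with wide uncertainty. Compound 4 is therefore expected near 1000 nM, with a range from 200 nM to 5000 nM, which amounts to an estimated no change at the digits printed from compound 3 to compound 4 (within the scatter).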

Compound 4, effective concentration (reported as EC, without a stated level of effect): 100 nM
Compound 4: the middle estimate sits 10-fold (1.00 log units) above what was measured; measured number below the stated range.
By their numbers in this assay, from the lowest: compound 1; then compound 4; then compounds 2 and 3 (each within the scatter of the next).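

Among these compounds, the sulfonyl side of the molecule, fixed in all the earlier compounds, does affect the result in this assay: putting 4-nitrophenyl in place of 3-methylphenyl on the sulfonyl sulfur gives a 10-fold lower number from compound 3 to compound 4 (1.00 log units; beyond the scatter), a step beyond the scatter. Until now, only changes on the carbonyl side had moved the number by more than the scatter, so this is a second place on the shared core where a change matters. Nothing available explains why this swap lowers the number.

The single swap removes a methyl group and brings in a nitro group, and the compounds shown cannot separate those two parts of the change, so it remains open what plain phenyl or 4-aminophenyl on the sulfonyl sulfur would give. Also open, as far as these compounds go, is whether 4-nitrophenyl on the sulfonyl sulfur and pyridin-3-yl on the carbonyl carbon would work together in one molecule.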